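Working notes: efficacy of compounds 1 to 4

A few compounds are considered here, and "the series" means these few. Any claim that something is new, unique, unknown or untested is made for them only; others in the source may bear on it.

Measured so far:
compound 1 `CC(C)[C@H](C(=O)Nc1ccccn1)c1ccc(Cl)cc1`: 92%
compound 2 `CC(C)[C@H](C(=O)Nc1cccnn1)c1ccc(Cl)cc1`: 101%
compound 3 `CC(C)(C)[C@H](C(=O)Nc1ncc(F)s1)c1ccc(Cl)cc1`: 92%

In a functional assay on CHO cells for agonist activity at Free fatty acid receptor 2 (Homo sapiens), read by cAMP accumulation (on this read-out lower numbers stand for smaller maximal responses and higher numbers for larger maximal responses), compound 3 gives 92%. Compound 3 thereby matches compound 1 at the digits read, and compound 2 lies a step away that stays within the scatter. Among the compounds with values here, the one measured step in the set, a number 9 percentage points higher from compound 1 to compound 2 (within the scatter), concerns the group on the amide-type nitrogen and is itself within the scatter; no measured pair touches the five-membered ring of compound 3.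

Compound 4 `CC(C)(C)[C@H](C(=O)Nc1ncc(C(O)(C(F)(F)F)C(F)(F)F)s1)c1ccc(Cl)cc1` differs from compound 3 by 2,2,2-trifluoro-1-hydroxy-1-(trifluoromethyl)ethyl in place of fluoro on an aromatic carbon. Within the data shown here, no measured step bears on this change, so the only anchor is the value of compound 3 itself. With nothing in the data pointing either way, the step is expected to stay within the scatter: a number 2 percentage points lower from compound 3 to compound 4 (within the scatter) is the estimated change in this assay. Compound 4 is therefore expected to give about 90%, with a range from 70% to 108%.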

Compound 4, largest response reached (reported as efficacy), in percent of the reference or control that the assay uses: 113%
Compound 4: the middle estimate sits 23 percentage points below what was measured; measured number above the stated range.
By their numbers in this assay, from the lowest: compounds 1, 3 and 2 (each within the scatter of the next); then compound 4.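

In this assay, within the data shown here, 2,2,2-trifluoro-1-hydroxy-1-(trifluoromethyl)ethyl in place of fluoro, on the aromatic carbon next to the ring sulfur, gives a number 21 percentage points higher from compound 3 to compound 4 (beyond the scatter), and this is the only step that lies beyond the scatter. This position therefore accepts a much larger group, one that brings a hydrogen-bond donor and a hydrogen-bond acceptor, with no loss of maximal response and with a modest gain. The data at hand offer no explanation for the rise.

As far as these compounds go, it remains open whether the hydroxyl or the trifluoromethyl groups of the new substituent carry the gain, which a hydroxymethyl, a 2-hydroxypropan-2-yl or a lone trifluoromethyl at the same carbon could test. From the compounds shown here alone, it is also open whether the gain holds with a carboxylic acid or an amine at this position.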